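A few compounds are considered here, and "the series" means these few. Any claim that something is new, unique, unknown or untested is made for them only; others in the source may bear on it.

Of the compounds shown here, two have so far been measured in a functional assay on aorta for antagonist activity at Alpha-1D adrenergic receptor (Rattus norvegicus); on this read-out lower numbers stand for tighter binding and higher numbers for weaker binding. Compound 1 `COc1ccccc1N1CCN(CCCNc2cncnc2C(=O)N(C)C)CC1` gives 50.1 nM in this assay, whereas compound 2 `CCOc1ccccc1N1CCN(CCCNc2ncccc2C(=O)N(C)C)CC1` gives 7.94 nM, the lower of the two numbers, with compound 1 standing beyond the scatter above it. The two structures differ in more than one place, so no single change between them can be read from the pair.

Compound 3 `CN(C)C(=O)c1cccnc1NCCCN1CCN(c2ccccc2C2CC2)CC1` has not yet been measured. It differs from compound 2 in one place: cyclopropyl in place of ethoxy on an aromatic carbon. The ethoxy leaves and a cyclopropyl enters on the six-membered aromatic ring of carbon only, so that 2-ethoxyphenyl becomes 2-cyclopropylphenyl. Going by the values given here, no measured pair shows this change, so the expectation rests on compound 2 alone, and a moderate loss is expected, a step of a 2.5-fold higher number from compound 2 to compound 3 (0.40 log units; beyond the scatter) beyond the scatter. Compound 3 is accordingly estimated at 20 nM, with a range from 6 nM to 70 nM.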

Compound 3, dissociation constant: 63.1 nM
Compound 3: middle estimate off by 3.2-fold (0.50 log units), on the low side, and the stated range covers the measured number.
By their numbers in this assay, from the lowest: compound 2; then compounds 1 and 3 (each within the scatter of the next).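

In this assay, going by these compounds alone, cyclopropyl in place of ethoxy on an aromatic carbon, ortho to a large group, gives a 7.9-fold higher number from compound 2 to compound 3 (0.90 log units; beyond the scatter) and is the first change that can be read on its own. Ethoxy and cyclopropyl have the same count of heavy atoms, so this position is not indifferent to which of the two groups it carries, even with that count unchanged. Nothing measured accounts for the step.

The compounds shown leave open how an ethyl, a propoxy or a plain hydrogen would read at this position, and so whether the step follows the loss of the ethoxy or the arrival of the ring. They also leave open whether the same change would give a similar step on the core of compound 1.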